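The source may report more compounds than this note shows. Statements on the series, on what has been measured and on what is new or still open speak of the compounds shown alone.

Measured so far in a functional assay on MDA-MB-231 cells (Homo sapiens) for inhibition, with a stated time of 72 h; on this read-out higher numbers stand for weaker inhibition and lower numbers for stronger inhibition:
Compound 2 `O=C(Nc1ccc(Cl)cc1)Nc1nc(Sc2c[nH]c3ccccc23)cc(N2CCCC2)n1` gives 5850 nM.
Compound 1 `O=C(Nc1ccccc1)Nc1nc(NC2CC2)cc(Sc2c[nH]c3ccccc23)n1` gives 7860 nM.
Compound 3 `O=C(Nc1ccc(Cl)cc1)Nc1nc(Sc2c[nH]c3ccccc23)cc(N2CCCCC2)n1` gives 10100 nM.

In this assay compound 2 has the lowest of the three numbers, but its gaps to compound 1 and to compound 3 both lie within the usual scatter, so no order among the three can be claimed. Compound 4 `Cc1cc(Cl)ccc1NC(=O)Nc1nc(Sc2c[nH]c3ccccc23)cc(N2CCCC2)n1` differs from compound 2 by methyl in place of hydrogen on an aromatic carbon. Going by the values given here, the only measured step, a 1.7-fold higher number from compound 2 to compound 3 (0.24 log units; within the scatter), alters a different part of the molecule, the ring attached to the shared core rather than the phenyl ring of the urea, and it stayed within the scatter. Compound 1 and compound 2 differ in two places at once, and their values sit within the scatter of each other. Among the compounds with values here, no measured step therefore speaks to the new methyl group, and a step of a 1.0-fold lower number from compound 2 to compound 4 (0.00 log units; within the scatter) is expected, that is, none beyond the scatter. The estimate for compound 4 in this assay is 5800 nM, with a range from 2500 nM to 14000 nM.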

Compound 4, half-maximal inhibitory concentration: 9440 nM
The estimate for compound 4 lay 1.6-fold (0.21 log units) below the measured number, within the range that was stated.
By their numbers in this assay, from the lowest: compounds 2, 1, 4 and 3 (each within the scatter of the next).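

In this assay the methyl group on the 4-chlorophenyl ring, ortho to a large group and meta to the chloro group, gives a 1.6-fold higher number from compound 2 to compound 4 (0.21 log units; within the scatter) and so stays inside the usual scatter. Going by these compounds alone, this is the first look at the phenyl ring of the urea with the chloro group kept in place, since the earlier step concerned the ring on the shared core, and it shows that this one added carbon leaves the read-out without a clear difference. No measurement here offers an explanation for this result.

On these data alone, whether a longer chain such as ethyl, or a group of another kind such as an amine or a carboxylic acid, would behave the same at this place stays open. Also open, as far as these compounds go, is whether the methyl group would give a similar result with piperidin-1-yl in place of pyrrolidin-1-yl.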